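A few compounds are considered here, and "the series" means these few. Any claim that something is new, unique, unknown or untested is made for them only; others in the source may bear on it.

Measured in a functional assay on MCF7 cells (Homo sapiens) for inhibition, read by sulforhodamine B assay, with a stated time of 72 h; on this read-out higher numbers stand for weaker inhibition and lower numbers for stronger inhibition:
compound 1 `COc1ccc2cc(C(C)c3nnc4n3N=C(c3ccc(Br)cc3)CS4)ccc2c1`: 11500 nM
compound 2 `CC(c1ccc(-c2ccccc2)c(F)c1)c1nnc2n1N=C(c1ccc(Cl)cc1)CS2`: 8700 nM
compound 3 `COc1ccc2cc(C(C)c3nnc4n3N=C(c3ccc(Cl)cc3)CS4)ccc2c1`: 10100 nM

Compounds 1 and 3 share one core; compound 2 carries another, and the difference between the two cores is not broken down here. All three numbers lie within the usual scatter of one another, so no order among them can be drawn from these data. One change has been measured once, from compound 3 to compound 1: bromo in place of chloro on an aromatic carbon, and it gave a 1.1-fold higher number from compound 3 to compound 1 (0.06 log units; within the scatter). For the measured compounds named here, compound 4 `CC(c1ccc(-c2ccccc2)c(F)c1)c1nnc2n1N=C(c1ccc(Br)cc1)CS2` is not yet measured; it arises from compound 2 by bromo in place of chloro on an aromatic carbon, the same change at a place described in the same words, so the single measured step is the only direct guide. On that basis the step is expected to be a 1.1-fold higher number from compound 2 to compound 4 (0.04 log units; within the scatter), essentially flat. In this assay compound 4 is therefore estimated at 9500 nM, with an expected range from 4500 nM to 20000 nM. Going by the values given here, the range is kept wide: only one measured step of this kind stands behind it.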

Compound 4, half-maximal inhibitory concentration: 7400 nM
For compound 4 the middle estimate is 1.3-fold (0.11 log units) above the measured one, within the range that was stated.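

In this assay, the exchange of 4-chlorophenyl for 4-bromophenyl gives a 1.2-fold lower number from compound 2 to compound 4 (0.07 log units; within the scatter), so the number stays flat on this second core as well. The two steps do not differ: the same change on two cores in this assay, a 1.1-fold higher number (0.06 log units; within the scatter) from compound 3 to compound 1 and a 1.2-fold lower number (0.07 log units; within the scatter) from compound 2 to compound 4, 1.3-fold (0.13 log units) apart, within the scatter of two such steps. The change therefore carries from one core to the other without a step beyond the scatter on either, but the opposite directions of the two small steps carry no meaning, and two pairs in one cell assay do not show that chloro and bromo are interchangeable on other cores or in other assays.

As far as these compounds go, all four compounds carry a halogen at this place, so it remains open whether an amine or a carboxylic acid there, on a six-membered aromatic ring of carbon only, would move the number beyond the scatter. Also open, from the compounds shown here alone, is whether a longer chain in place of the methyl on the linking carbon would change the number on either core.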